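Replacing propyl with phenyl in a short series

The compounds below may be only part of what the source reports. "The series", "measured", "known", "first", "only" and "open" are said of these compounds alone.

Measured so far:
- compound 1 `CCCCCc1nc2ccccc2[nH]1`: 3.43
- compound 2 `CCCCCCCc1nc2ccccc2[nH]1`: 4.43

Both values come from a physicochemical assay for lipophilicity; a lower number here means a more polar compound, a higher number a more lipophilic compound. Of the two numbers, compound 2 at 4.43 stands highest, and the other number is that of compound 1 at 3.43.

The next compound to be measured is compound 3 `c1ccc(CCCCc2nc3ccccc3[nH]2)cc1`. The change is phenyl in place of propyl on a saturated chain carbon, four bonds along the chain from an aromatic carbon.

Among the compounds with values here, only one measured step bears on this change: a number 1.00 log units higher from compound 1 to compound 2 (beyond the scatter). That step adds ethyl in place of hydrogen, lengthening a chain, so it is only a loose guide. Within the data shown here, no measured pair exchanges a chain end for a ring, and the direction in this assay cannot be read directly from the series. A small downward step is expected, though a wide range is kept open on both sides.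

The estimated step is a number 0.33 log units lower from compound 2 to compound 3 (beyond the scatter), smaller than the one measured. For compound 3 the estimated value is 4.1, with an expected range from 3.7 to 4.5.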

Compound 3, partition coefficient: 4.96
Beside the measured number, compound 3's estimate is 0.86 log units below it, and the stated range ends below it.
By their numbers in this assay, from the lowest: compound 1; then compound 2; then compound 3.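

In this assay, the exchange of propyl for phenyl on a saturated chain carbon, four bonds along the chain from an aromatic carbon, gives a number 0.53 log units higher from compound 2 to compound 3 (beyond the scatter), so the upward movement at this place is not confined to lengthening a chain. Set against the shorter chain of compound 1, the exchange of methyl for phenyl at the same place gives a number 1.53 log units higher from compound 1 to compound 3 (beyond the scatter), and this step is printed as large, whereas the chain extension in the earlier pair was modest. The series now holds one open-chain change and two ring-for-chain changes, all pointing upward, but no measurement offers an explanation for the size of either new step.

The compounds shown leave open whether the rise follows the aromatic ring itself or simply the larger group, since a saturated ring such as cyclohexyl or a longer chain at this place would be needed to separate the two. They also leave open how far the number in this assay would move with a group carrying an amine or a carboxylic acid at this place.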